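Swapping a Bromophenyl for a Furanoyl Group

The source may report more compounds than this note shows. Statements on the series, on what has been measured and on what is new or still open speak of the compounds shown alone.

Of the compounds shown here, three sharing one core have been measured in a functional assay on Jurkat cells for inhibition of nuclear factor NF-kappa-B complex (Homo sapiens); a lower number here means a stronger inhibitor, a higher number a weaker inhibitor. Compound 1 `CCOC(=O)c1cnc(CC)nc1NN1C(=O)C=C(C)C1=O` gives 10000 nM. Compound 2 `CCOC(=O)c1cnc(-c2ccccc2)nc1NN1C(=O)C=C(C)C1=O` gives 100 nM, and compound 3 `CCOC(=O)c1cnc(-c2cccc(Br)c2)nc1NN1C(=O)C=C(C)C1=O` gives 700 nM. Compound 3 thus holds the second highest of the three numbers: the step of a 7.0-fold higher number from compound 2 to compound 3 (0.85 log units; beyond the scatter) separates it from compound 2, while a 14-fold lower number from compound 1 to compound 3 (1.15 log units; beyond the scatter) separates it from compound 1. Compound 4 `CCOC(=O)c1cnc(C(=O)c2ccco2)nc1NN1C(=O)C=C(C)C1=O` has not yet been measured; it differs from compound 3 by (furan-2-yl)carbonyl in place of 3-bromophenyl on an aromatic carbon. All measured steps concern this same position: a 100-fold lower number from compound 1 to compound 2 (2.00 log units; beyond the scatter) and a 14-fold lower number from compound 1 to compound 3 (1.15 log units; beyond the scatter) show large drops when phenyl or 3-bromophenyl replaces ethyl, and a 7.0-fold higher number from compound 2 to compound 3 (0.85 log units; beyond the scatter) shows a rise when bromo replaces hydrogen. None of them involves a carbonyl or a five-membered aromatic ring with 1 hetero atom, so they offer only a rough guide and the uncertainty is wide. Compound 4 is therefore expected to give about 1000 nM, with a range from 200 nM to 5000 nM. The expected step is a 1.4-fold higher number from compound 3 to compound 4 (0.15 log units; within the scatter), which would stay within the scatter.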

Compound 4, half-maximal inhibitory concentration: 700 nM
Compound 4: middle estimate off by 1.4-fold (0.15 log units), on the high side; the range from low to high includes it.
By their numbers in this assay, from the lowest: compound 2; then compounds 3 and 4 (each within the scatter of the next); then compound 1.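

In this assay, the exchange gives no change at the digits printed from compound 3 to compound 4 (within the scatter): this position accepts a five-membered aromatic ring attached through a carbonyl, with hydrogen-bond acceptors that 3-bromophenyl lacks, and the number stays level. Against the other two groups, the same exchange gives a 7.0-fold higher number from compound 2 to compound 4 (0.85 log units; beyond the scatter) and a 14-fold lower number from compound 1 to compound 4 (1.15 log units; beyond the scatter), so (furan-2-yl)carbonyl keeps much of the gain over ethyl but does not reach the level of plain phenyl. No measurement available here accounts for these two quite different groups giving matching numbers.

Going by these compounds, the carbonyl and the furan ring change together, so their separate contributions remain unknown; a benzoyl group or a furan-2-yl group attached directly to the core would pull them apart. On these data alone, how an amine or a longer carbon chain would behave at this position also remains open.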